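Swapping the pyrimidine for a benzothiazole

This account rests on a few compounds, and the source may have more. Where it says the series, first, only, none or still open, it means among the compounds named here.

In an ADME assay on microsomes from liver (Mus musculus) for metabolic stability, read by LC-MS, with a stated time of 10 min, tested at 0.5 uM (a higher number here means that more of the compound is left, a lower number that less of the compound is left), compound 3 `c1cnc(CN(CCCN2CCNCC2)[C@H]2CCCc3cccnc32)nc1` gives 78%, the highest of the three measured numbers: compound 2 `c1ccc2c(c1)CN[C@@H](CN(CC[C@H]1CCCNC1)[C@H]1CCCc3cccnc31)C2` gives 56% and compound 1 `CN1CCN(CCCN(C[C@H]2Cc3ccccc3CN2)[C@H]2CCCc3cccnc32)CC1` gives 53%, both lying beyond the scatter below it. Compound 4 `c1cnc2c(c1)CCC[C@@H]2N(CCCN1CCNCC1)Cc1nc2ccccc2s1` differs from compound 3 in one place: 1,3-benzothiazol-2-yl in place of pyrimidin-2-yl on a saturated chain carbon bound to an amine nitrogen. Within the data shown here, the only measured step, a number 3 percentage points higher from compound 1 to compound 2 (within the scatter), alters a different part of the molecule, so no measured step bears on this change and its direction cannot be read from the data. A step of a number 23 percentage points lower from compound 3 to compound 4 (beyond the scatter) toward less compound remaining is nonetheless expected, with wide uncertainty. For compound 4 the result in this assay is estimated at 55%, within 30% to 78%.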

Compound 4, percent of the compound remaining: 45%
For compound 4 the middle estimate is 10 percentage points above the measured one; measured number inside the range.
By their numbers in this assay, from the lowest: compounds 4, 1 and 2 (each within the scatter of the next, the first and the last beyond it); then compound 3.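

Placing 1,3-benzothiazol-2-yl where pyrimidin-2-yl stood gives a number 33 percentage points lower from compound 3 to compound 4 (beyond the scatter) in this assay and thus shows that the group at this position, on a saturated chain carbon bound to an amine nitrogen, can strongly change how much compound is left. The earlier step touched another part of the molecule and could not show this. No available evidence explains the fall.

A 1,3-thiazol-2-yl group at this position could help separate the contribution of the sulfur-containing ring from that of the added carbon ring. From the compounds shown here alone, whether the same swap would have a similar effect alongside a different side chain remains open.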